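A few compounds are considered here, and "the series" means these few. Any claim that something is new, unique, unknown or untested is made for them only; others in the source may bear on it.

Three compounds share a core and differ in the group attached to one aromatic carbon of that core. Compound 2 `c1ccc(Oc2ccc3c(NCCCNCc4ccco4)ccnc3c2)cc1` and compound 3 `CC(C)(C)c1ccc(Oc2ccc3c(NCCCNCc4ccco4)ccnc3c2)cc1` carry related side groups, while compound 1 `COc1ccc(F)cc1CNCCCNc1ccnc2cc(Cc3cc(C)cc(C)c3)ccc12` carries a different one. In an ADME assay for permeability, using PAMPA, with a stated time of 30 min, at pH 7.4 (on this read-out higher numbers stand for higher permeability and lower numbers for lower permeability), compound 2 gives 317 10^-6 cm/s, and compound 3 gives 317 10^-6 cm/s. Compound 1 gives 23 10^-6 cm/s in this assay, so compound 2 and compound 3 stand together at the top of the three numbers, with compound 1 well beneath them.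

Among the compounds with values here, the one measured step that can be compared here is no change at the digits printed from compound 2 to compound 3 (within the scatter). It shows that adding a bulky group to the aromatic ring of the side group left the read-out where it was.

Compound 4 `COc1ccc(-c2ccc3c(NCCCNCc4ccco4)ccnc3c2)cc1` has not yet been measured. It differs from compound 2 as follows: 4-methoxyphenyl in place of phenoxy on an aromatic carbon. Within the data shown here, no measured step repeats this exact change; the nearest guide is the step from compound 2 to compound 3, which did not move the number. On that basis a step of about a 1.1-fold lower number from compound 2 to compound 4 (0.05 log units; within the scatter) is expected, staying within the scatter. Compound 4 is therefore estimated to give 280 10^-6 cm/s in this assay, with a range from 140 10^-6 cm/s to 450 10^-6 cm/s.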

Compound 4, apparent permeability: 237 10^-6 cm/s
The estimate for compound 4 lay 1.2-fold (0.07 log units) above the measured number; the range from low to high includes it.
By their numbers in this assay, from the lowest: compound 1; then compounds 4, 2 and 3 (each within the scatter of the next).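

In this assay, putting 4-methoxyphenyl in place of phenoxy on this aromatic carbon gives a 1.3-fold lower number from compound 2 to compound 4 (0.13 log units; within the scatter), so the read-out stays within the scatter. The earlier step only added tert-butyl to the ring of the phenoxy group, leaving that group joined to the shared core through its oxygen, whereas this step replaces the whole group with one joined directly by its ring and carrying a methoxy group. Compounds 2, 3 and 4 therefore show that, for this read-out, a change in how the ring is joined at this position can also pass without a shift beyond the scatter, but no measurement shown here offers an explanation for the result.

Going by these compounds, the loss of the linking oxygen and the gain of the methoxy group arrive together in compound 4, so their separate contributions remain open. The compounds shown also leave open how this read-out would respond to an amine or a carboxylic acid on that ring, or to a longer chain in place of the methoxy group.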